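A few compounds are considered here, and "the series" means these few. Any claim that something is new, unique, unknown or untested is made for them only; others in the source may bear on it.

Working notes on the series in a functional assay on SGC-7901 cells (Homo sapiens) for inhibition, read by MTT assay, with a stated time of 24 h; on this read-out higher numbers stand for weaker inhibition and lower numbers for stronger inhibition: compound 1 `CC1(C)[C@H]2CC[C@]1(C)N(Cc1cn(-c3ccccc3F)nn1)C(=O)C2` gives 300 nM, compound 2 `CC1(C)[C@H]2CC[C@]1(C)N(Cc1cn(-c3cccc(Cl)c3)nn1)C(=O)C2` gives 510 nM and compound 3 `CC1(C)[C@H]2CC[C@]1(C)N(Cc1cn(-c3ccc(O)cc3)nn1)C(=O)C2` gives 330 nM, which places compound 3 within the scatter of both others. Compound 4 `Cc1ccccc1-n1cc(CN2C(=O)C[C@@H]3CC[C@@]2(C)C3(C)C)nn1` carries 2-methylphenyl in place of 4-hydroxyphenyl on an aromatic nitrogen. Three measured swaps at this same place bear on it: a 1.7-fold higher number from compound 1 to compound 2 (0.23 log units; within the scatter), a 1.1-fold higher number from compound 1 to compound 3 (0.04 log units; within the scatter) and a 1.5-fold lower number from compound 2 to compound 3 (0.19 log units; within the scatter). All three stay within the scatter, so no step beyond the scatter is expected in this assay. The expected move is a 1.1-fold higher number from compound 3 to compound 4 (0.03 log units; within the scatter). The estimate for compound 4 is 350 nM, with an expected range of 150 nM to 800 nM.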

Compound 4, half-maximal inhibitory concentration: 350 nM
Estimate against measurement, compound 4: no gap at the digits printed, within the range that was stated.
By their numbers in this assay, from the lowest: compounds 1, 3, 4 and 2 (each within the scatter of the next).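

In this assay, 2-methylphenyl in place of 4-hydroxyphenyl gives a 1.1-fold higher number from compound 3 to compound 4 (0.03 log units; within the scatter) even though the hydrogen-bond donor and acceptor of the leaving group are gone, so that change in count shows no effect beyond the scatter at this position. The swaps measured against the other two compounds also stay within the scatter: a 1.5-fold lower number from compound 2 to compound 4 (0.16 log units; within the scatter) for 2-methylphenyl in place of 3-chlorophenyl, and a 1.2-fold higher number from compound 1 to compound 4 (0.07 log units; within the scatter) for methyl in place of fluoro on an aromatic carbon. No evidence is at hand on what lies behind these results. Going by these compounds, whether an amine or a carboxylic acid on the phenyl ring would move the number beyond the scatter stays open.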